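Swapping the Octyl Chain for a Dimethoxyphenyl Ring

The source may report more compounds than this note shows. Statements on the series, on what has been measured and on what is new or still open speak of the compounds shown alone.

Compound 1 `CCCCCCCCNc1nc(SCc2ccc(C(F)(F)F)cc2)nc2ccccc12` was tested in a functional assay on MGC-803 cells (Homo sapiens) for cytotoxicity, read by MTT assay, with a stated time of 72 h (on this read-out higher numbers stand for weaker inhibition and lower numbers for stronger inhibition), where compound 1 gives 12600 nM. Among the three measured compounds it stands second highest; its nearest neighbour is compound 3 `O=[N+]([O-])c1ccc(Nc2nc(SCc3ccc(C(F)(F)F)cc3)nc3ccccc23)cc1`, which in this assay gives 8170 nM, and furthest from it is compound 2 `FC(F)(F)c1ccc(CSc2nc(Nc3cccc(Br)c3)c3ccccc3n2)cc1`, which in this assay gives 23700 nM. Compound 4 `COc1ccc(Nc2nc(SCc3ccc(C(F)(F)F)cc3)nc3ccccc23)cc1OC` has not yet been measured. It differs from compound 1 in one place: 3,4-dimethoxyphenyl in place of octyl on a nitrogen on an aromatic ring. The change is best read alongside the two measured steps that replace the same octyl group on the same nitrogen with an aromatic ring: a 1.9-fold higher number from compound 1 to compound 2 (0.27 log units; within the scatter) and a 1.5-fold lower number from compound 1 to compound 3 (0.19 log units; within the scatter). Between those two aryl compounds, a 2.9-fold lower number from compound 2 to compound 3 (0.46 log units; beyond the scatter). Neither aryl replacement moved the number beyond the scatter from compound 1, so the data give no reason to expect that a third aryl group, the 3,4-dimethoxyphenyl, would behave differently, though no measured compound carries that group. Compound 4 is therefore expected to sit close to compound 1, with a 1.0-fold higher number from compound 1 to compound 4 (0.01 log units; within the scatter). The estimate for compound 4 in this assay is 13000 nM, with a range from 5000 nM to 35000 nM.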

Compound 4, half-maximal inhibitory concentration: 16300 nM
Compound 4: the middle estimate sits 1.3-fold (0.10 log units) below what was measured, and the stated range covers the measured number.
By their numbers in this assay, from the lowest: compounds 3, 1, 4 and 2 (each within the scatter of the next, the first and the last beyond it).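

In this assay, the 3,4-dimethoxyphenyl group, which carries a ring and hydrogen-bond acceptors that octyl lacks, leaves the number within the scatter of the octyl compound, with a 1.3-fold higher number from compound 1 to compound 4 (0.11 log units; within the scatter). Within the data shown here, this third aryl group also stays within the scatter of both other aryl compounds, with a 2.0-fold higher number from compound 3 to compound 4 (0.30 log units; within the scatter) and a 1.5-fold lower number from compound 2 to compound 4 (0.16 log units; within the scatter), so the only step beyond the scatter at this position remains a 2.9-fold lower number from compound 2 to compound 3 (0.46 log units; beyond the scatter). No measurement is at hand that bears on this result.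

The compounds shown leave open whether an amine or a carboxylic acid on the aryl ring, or an alkyl chain shorter than octyl on the same nitrogen, would move the number beyond the scatter from compound 1. They also leave open whether any group on this nitrogen could take the number well past that of compound 3 at 8170 nM, and whether the small steps seen here would hold if the trifluoromethyl group elsewhere on the shared scaffold gave way to a nitrile.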